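This account rests on a few compounds, and the source may have more. Where it says the series, first, only, none or still open, it means among the compounds named here.

Within the data shown here, in a physicochemical assay for lipophilicity, using the shake flask method (on this read-out higher numbers stand for higher lipophilicity and lower numbers for lower lipophilicity), compound 1 `C[C@H](Oc1ccc2ncc(/C=C/S(=O)(=O)O)c(C3CC3)c2c1)c1c(Cl)ccc(F)c1Cl` gives 2.5, the higher of the two numbers measured so far, while compound 2 `C[C@H](Oc1ccc2ncc(/C=C/C(=O)NC(CC(=O)O)CC(=O)O)c(C3CC3)c2c1)c1c(Cl)ccc(F)c1Cl` gives 0.4. The compound still to be measured, compound 3 `C[C@H](Oc1ccc2ncc(S(=O)(=O)CC(=O)O)c(C3CC3)c2c1)c1c(Cl)ccc(F)c1Cl`, differs from compound 1 in one place: a group of 7 heavy atoms (2 carbon, 4 oxygen, 1 sulfur; no ring) in place of a group of 6 heavy atoms (2 carbon, 3 oxygen, 1 sulfur; no ring), on an aromatic carbon. The entering group is (carboxymethyl)sulfonyl, and it sits on an aromatic carbon, ortho to a cyclopropyl group. Among the measured compounds shown here, only one measured step bears on this change, a number 2.10 log units lower from compound 1 to compound 2 (beyond the scatter), and it is a large one. It is a loose guide, however, as it put (2-carboxy-1-(carboxymethyl)ethyl)carbamoyl in place of sulfo, which is not the change made in compound 3. A smaller fall in this assay is therefore expected, estimated as a number 0.70 log units lower from compound 1 to compound 3 (beyond the scatter). For compound 3 the expected value is 1.8, with an estimated range from 1 to 2.6.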

Compound 3, distribution coefficient: 2.5
Compound 3: the middle estimate sits 0.70 log units below what was measured; measured number inside the range.
By their numbers in this assay, from the lowest: compound 2; then compounds 1 and 3 (each within the scatter of the next).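

On the aromatic carbon ortho to a cyclopropyl group, placing (carboxymethyl)sulfonyl where the group of 6 heavy atoms stood gives, in this assay, no change at the digits printed from compound 1 to compound 3 (within the scatter). Among these compounds, the earlier record held only one step at this place, a number 2.10 log units lower from compound 1 to compound 2 (beyond the scatter), so compound 3 shows that a large fall does not come with every replacement of this side group: here, a group with one more heavy atom and one more hydrogen-bond acceptor leaves the read-out level with compound 1. No measurement at hand accounts for this result.

On these data alone, it remains open whether a methylsulfonyl group or an amine on this same carbon would read the same way. Also open, as far as these compounds go, is what a longer chain between the sulfonyl and the carboxylic acid would do.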